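This account rests on a few compounds, and the source may have more. Where it says the series, first, only, none or still open, it means among the compounds named here.

Compound 1 `O=C1C=C(Nc2ccccc2)C(=O)c2scnc21` and compound 2 `CCOc1ccc(NC2=CC(=O)c3ncsc3C2=O)cc1` share a core that also appears in compound 3 `COC1=CC(=O)c2ncsc2C1=O`, for which in a functional assay on HepG2 cells (Homo sapiens) for cytotoxicity, read by MTT assay (a higher number here means a weaker inhibitor, a lower number a stronger inhibitor), compound 3 gives "not tested" (no result reported). In this assay compound 1 gives 14.7 ug/mL and compound 2 gives 23.6 ug/mL; the step of a 1.6-fold higher number from compound 1 to compound 2 (0.21 log units; within the scatter) places compound 2 at the higher of the two numbers, yet within the scatter of compound 1. Compound 4 `O=C1C=C(Nc2ccc(OC(F)(F)F)cc2)C(=O)c2scnc21` follows from compound 2 by the change (trifluoromethyl in place of ethyl on an oxygen on an aromatic ring). Among the measured compounds shown here, the only measured step touching this part of the structure, a 1.6-fold higher number from compound 1 to compound 2 (0.21 log units; within the scatter), lies within the scatter, so no step beyond the scatter is expected here either. For compound 4 the number in this assay is estimated at 22 ug/mL, between 10 ug/mL and 50 ug/mL, a step of a 1.1-fold lower number from compound 2 to compound 4 (0.03 log units; within the scatter) that is expected to stay within the scatter.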

Compound 4, half-maximal inhibitory concentration: > 100 ug/mL
Compound 4: no number, only a limit; the forecaster's own chance of this, stated with the estimate: 10%; middle value at least 4.5-fold (0.65 log units) away from the limit.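

In this assay, trifluoromethyl in place of ethyl on an oxygen on an aromatic ring gives an at least 4.2-fold higher number from compound 2 to compound 4 (0.62 log units; beyond the scatter), and trifluoromethoxy in place of hydrogen on an aromatic carbon gives an at least 6.8-fold higher number from compound 1 to compound 4 (0.83 log units; beyond the scatter). This aromatic carbon therefore does respond to its substituent, which the ethoxy in place of hydrogen, within the scatter, had not shown. For compound 4 the result is a limit of the assay, not a number: the limit of > 100 ug/mL in this assay, at which 1 of the 4 values shown sits.

Going by these compounds, how far compound 4 lies past that limit stays open. So does whether an amine or a longer chain on that oxygen would follow compound 2 or compound 4.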